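Halogenated anilide variation on a triazolyl-methoxy chromene ester

The compounds below may be only part of what the source reports. "The series", "measured", "known", "first", "only" and "open" are said of these compounds alone.

Measured compounds:
Compound 1, `CCOC(=O)C1=Cc2ccccc2OC1(OCc1cn(-c2cccc(OC)c2)nn1)C(F)(F)F`, > 150000 nM in a functional assay on A549 cells (Homo sapiens) for inhibition, read by MTT assay, with a stated time of 24 h; a lower number here means a stronger inhibitor, a higher number a weaker inhibitor
Compound 2, `CCOC(=O)C1=Cc2ccccc2OC1(OCc1cn(CC(=O)Nc2ccc(C)cc2)nn1)C(F)(F)F`, 54300 nM
Compound 3, `CCOC(=O)C1=Cc2ccccc2OC1(OCc1cn(CC(=O)Nc2ccccc2F)nn1)C(F)(F)F`, 50100 nM

Compound 1 gives only a limit in this assay, (the limit of > 150000 nM in this assay, at which 1 of the 3 values shown sits), and not a number. Compound 2 and compound 3 each give a number, and the two sit within the usual scatter of each other, so compound 3 stands beside compound 2 rather than apart from it; the third value shown is the limit of compound 1. The steps from the limit are an at least 2.7-fold lower number from compound 1 to compound 2 (0.44 log units; beyond the scatter) and an at least 2.9-fold lower number from compound 1 to compound 3 (0.47 log units; beyond the scatter), both at least modest, while the step between the two anilides, a 1.1-fold lower number from compound 2 to compound 3 (0.03 log units; within the scatter), lies within the scatter.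

Compound 4, `CCOC(=O)C1=Cc2ccccc2OC1(OCc1cn(CC(=O)Nc2ccc(I)cc2Cl)nn1)C(F)(F)F`, is not yet measured. It differs from compound 3 by 2-chloro-4-iodophenyl in place of 2-fluorophenyl on an amide-type nitrogen. Within the data shown here, the only measured step that bears on this place is the one from compound 2 to compound 3, which was within the scatter, so the aryl group on the amide-type nitrogen has so far made no difference beyond noise. Compound 4 is therefore expected to show a step of about a 1.1-fold lower number from compound 3 to compound 4 (0.05 log units; within the scatter) in this assay, that is, none beyond the scatter. The estimate for compound 4 is 45000 nM, with a range from 15000 nM to 140000 nM.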

Compound 4, half-maximal inhibitory concentration: 22300 nM
The estimate for compound 4 lay 2.0-fold (0.30 log units) above the measured number, and the stated range covers the measured number.
By their numbers in this assay, from the lowest: compound 4; then compounds 3 and 2 (each within the scatter of the next). At a limit, above all of these: compound 1.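

In this assay, the aryl group on the amide-type nitrogen now makes a difference beyond the scatter, which the two earlier anilides had not shown: the change to 2-chloro-4-iodophenyl gives a 2.2-fold lower number from compound 3 to compound 4 (0.35 log units; beyond the scatter) and a 2.4-fold lower number from compound 2 to compound 4 (0.39 log units; beyond the scatter), both modest. Compound 4 thus has the lowest number among the compounds shown, and the full change at the aromatic nitrogen, to ((2-chloro-4-iodophenyl)carbamoyl)methyl, gives an at least 6.7-fold lower number from compound 1 to compound 4 (0.82 log units; beyond the scatter). Compound 1 stands at a limit and not at a number: the limit of > 150000 nM in this assay, at which 1 of the 4 values shown sits.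

Neither the chlorine nor the iodine appears alone on the aryl group in the compounds shown, so it remains open whether one of the two atoms accounts for the step or whether both are needed. Also open, going by these compounds, is how this assay would read with an amine or a carboxylic acid on that aryl group, or with a longer chain in place of the methyl in the carbamoylmethyl group, and even the best number here leaves compound 4 as a weak inhibitor in absolute terms.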